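A few compounds are considered here, and "the series" means these few. Any claim that something is new, unique, unknown or untested is made for them only; others in the source may bear on it.

Compound 1 `CCC(C)(C)Cc1c[nH]c(CCc2ccc(-c3ccncc3)cc2)n1` gives 101 nM in an in vitro assay on CHO cells for displacement of a labelled ligand from Bombesin receptor subtype-3 (Homo sapiens), read by scintillation counting, with a stated time of 2 h; on this read-out higher numbers stand for weaker inhibition and lower numbers for stronger inhibition. Compound 2 `CCC(C)(C)Cc1c[nH]c(CCc2ccc(-n3cccn3)cc2)n1` gives 33 nM in this assay, the lowest of the two numbers shown; the only step, a 3.1-fold lower number from compound 1 to compound 2 (0.49 log units; beyond the scatter), is modest but beyond the scatter. Compound 3 `CCC(C)(C)Cc1c[nH]c(CCc2ccc(-n3ncnn3)cc2)n1` carries the change (2H-tetrazol-2-yl in place of 1H-pyrazol-1-yl on an aromatic carbon). Within the data shown here, no measured step bears directly on this change; the one step measured concerns a different exchange at the same position and cannot set a direction here. For compound 3 the expected step is a 1.5-fold higher number from compound 2 to compound 3 (0.18 log units; within the scatter), meaning a number within the scatter of compound 2 in this assay. Compound 3 is thus estimated at 50 nM, with a range from 15 nM to 160 nM.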

Compound 3, half-maximal inhibitory concentration: 205 nM
Estimate against measurement, compound 3: 4.1-fold (0.61 log units) below, outside the stated range (above it).
By their numbers in this assay, from the lowest: compound 2; then compound 1; then compound 3.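

In this assay, this position on the six-membered aromatic ring distinguishes between two five-membered aromatic rings: 2H-tetrazol-2-yl in place of 1H-pyrazol-1-yl gives a 6.2-fold higher number from compound 2 to compound 3 (0.79 log units; beyond the scatter). The 2H-tetrazol-2-yl group also compares unfavourably with pyridin-4-yl, with a 2.0-fold higher number from compound 1 to compound 3 (0.31 log units; beyond the scatter). No evidence is available on the cause of either step.

Among these compounds, whether the number follows the count of ring hetero atoms remains open, with only two five-membered rings to compare. A triazolyl or an imidazolyl group at this position would test that directly.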